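This account rests on a few compounds, and the source may have more. Where it says the series, first, only, none or still open, it means among the compounds named here.

Working notes on a set of chalcone-type pyrazoles tested in a functional assay on DU-145 cells (Homo sapiens) for inhibition, read by sulforhodamine B assay, with a stated time of 48 h; on this read-out higher numbers stand for weaker inhibition of growth and lower numbers for stronger inhibition of growth.

Within the data shown here, compound 1 `COc1cc(-c2cc(/C=C/C(=O)c3ccc(N)cc3)[nH]n2)cc(OC)c1OC` gives 4050 nM in this assay, the highest of the three numbers measured so far. Among the measured compounds shown here, compound 2 `COc1ccc(C(=O)/C=C/c2cc(-c3cc(OC)c(OC)c(OC)c3)n[nH]2)cc1OC` gives 1840 nM, and the change from compound 1 to compound 2, 4-aminophenyl in place of 3,4-dimethoxyphenyl on a carbonyl carbon read in reverse, is a step of a 2.2-fold lower number from compound 1 to compound 2 (0.34 log units; beyond the scatter), the only step in the set that falls beyond the scatter. Compound 3 `COc1ccc(C(=O)/C=C/c2cc(-c3cc(OC)c(OC)c(OC)c3)n[nH]2)cc1` gives 2830 nM; the step of a 1.4-fold lower number from compound 1 to compound 3 (0.16 log units; within the scatter) stays within the scatter, so compounds 1 and 3 cannot be told apart on this read-out.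

The change from compound 2 to compound 3 is hydrogen in place of methoxy on an aromatic carbon and gives a 1.5-fold higher number from compound 2 to compound 3 (0.19 log units; within the scatter), again within the scatter. The same kind of change now carries compound 1 to compound 4 `COc1ccc(-c2cc(/C=C/C(=O)c3ccc(N)cc3)[nH]n2)cc1OC`, described as hydrogen in place of methoxy on an aromatic carbon. The two cores differ as given above under the difference between compound 2 and compound 1. The surroundings of the change are not identical: in compound 4 the site is also meta to a methoxy group, which does not appear for compound 3, so the two changes are of the same kind rather than the same.

Resting on the measured pair, the step from compound 1 to compound 4 in this assay is expected to be a 1.5-fold higher number from compound 1 to compound 4 (0.17 log units; within the scatter), set beside a 1.5-fold higher number from compound 2 to compound 3 (0.19 log units; within the scatter). For the measured compounds named here, compound 4 is therefore estimated at 6000 nM, with a range from 3000 nM to 12000 nM, the width reflecting that only one example of the change exists in the set.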

Compound 4, concentration for total growth inhibition: 13500 nM
The estimate for compound 4 lay 2.3-fold (0.35 log units) below the measured number, and the stated range ends below it.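

In this assay, hydrogen in place of methoxy on an aromatic carbon of compound 1 gives a 3.3-fold higher number from compound 1 to compound 4 (0.52 log units; beyond the scatter), so on this core the loss of that methoxy group weakens inhibition of growth by more than the scatter. Set beside the one earlier example of this change, the new step cannot be told apart from it: the same change on two cores in this assay, a 1.5-fold higher number (0.19 log units; within the scatter) from compound 2 to compound 3 and a 3.3-fold higher number (0.52 log units; beyond the scatter) from compound 1 to compound 4, 2.2-fold (0.34 log units) apart, within the scatter of two such steps. Among these compounds, the change can thus be carried between these two cores with no measured difference in its size, but only the step on the core of compound 1 lies beyond the scatter, and two examples, whose sites have different surroundings, show neither that the size is fixed nor what sets it.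

Still open, as far as these compounds go, is how a hydroxy group, an amine or a longer chain such as ethoxy would compare with methoxy and hydrogen on this aromatic carbon. Also open, from the compounds shown here alone, is whether the size of the step would hold on cores other than these two, since each core carries the change only once.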